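The source may hold more compounds than are shown below. What is called first, only, known or untested is meant among the compounds shown, and "the series" means these compounds.

Compound 1 `O=C(CCc1ccccc1)Nc1nc2ccccc2c(=O)s1` is the parent of the pair; in an in vitro assay on cells for inhibition of Amine oxidase [flavin-containing] B (Homo sapiens), read by fluorescence and Amplex Red, with stated times of 30 min and 45 min (a higher number here means a weaker inhibitor, a lower number a stronger inhibitor), compound 1 gives 17.6 nM. For the measured compounds named here, compound 2 `O=C(CCc1ccccc1F)Nc1nc2ccccc2c(=O)s1` gives 11.2 nM in this assay; it carries the lowest of the two numbers so far, though the step of a 1.6-fold lower number from compound 1 to compound 2 (0.20 log units; within the scatter) does not separate it from compound 1. Compound 3 `O=C(CCc1ccc(Cl)c(Cl)c1)Nc1nc2ccccc2c(=O)s1` differs from compound 2 by 3,4-dichlorophenyl in place of 2-fluorophenyl on a saturated chain carbon, two bonds along the chain from a carbonyl carbon. Going by the values given here, the only step that bears on this change, fluoro in place of hydrogen on an aromatic carbon, lay within the scatter, so no step beyond the scatter is expected in this assay. Compound 3 is therefore estimated at 10 nM, range 4 nM to 30 nM, an expected step of a 1.1-fold lower number from compound 2 to compound 3 (0.05 log units; within the scatter).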

Compound 3, half-maximal inhibitory concentration: > 10000 nM
Compound 3: a limit, no number; the forecaster's own chance of this, stated with the estimate: 2%; at least 1000-fold (3.00 log units) between middle value and limit.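

With 3,4-dichlorophenyl on this saturated chain carbon, the change is no longer small: in this assay the replacement of 2-fluorophenyl gives an at least 890-fold higher number from compound 2 to compound 3 (2.95 log units; beyond the scatter), and the replacement of phenyl gives an at least 560-fold higher number from compound 1 to compound 3 (2.75 log units; beyond the scatter). The earlier fluoro step stayed within the scatter, so the pair alone gave no sign that the aryl group here could shift the reading this far. The reading for compound 3 is a limit of the assay, not a number: the limit of > 10000 nM in this assay, at which 1 of the 3 values shown sits.

Going by these compounds, whether a single chlorine on the phenyl ring is enough for such a step remains open. So does the outcome with a methoxy group on that ring or with a longer chain.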